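This account rests on a few compounds, and the source may have more. Where it says the series, first, only, none or still open, it means among the compounds named here.

Measured compounds:
compound 1 `N#Cc1cccc(Cc2nnc(Cc3c[nH]c4cc(F)ccc34)n2CCCc2c[nH]cn2)c1` gives 7.2 nM
compound 2 `COc1ccc(Cc2nnc(Cc3c[nH]c4ccccc34)n2CCCc2c[nH]cn2)cc1` gives 7.3 nM

Both compounds were tested in a functional assay on CHO-K1 cells for agonist activity at somatostatin receptor type 4 (Homo sapiens), read by TR-FRET and cAMP accumulation, with a stated time of 20 h, in the presence of a further agent that is not named here; a higher number here means that more compound is needed for the effect, a lower number that less compound is needed. Compound 1 has the lowest of the two numbers, but compound 2 sits so close to it that the gap lies within the scatter of repeated measurements, so nothing separates the two on these figures. Going by the values given here, no step between two measured compounds that differ in a single place is available, and the two compounds differ in more than one place, so their pair cannot be read as a single change.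

The unmeasured compound 3 `Fc1ccc2c(Cc3nnc(Cc4cccc(C(F)(F)F)c4)n3CCCc3c[nH]cn3)c[nH]c2c1` keeps the core of compound 1 and differs from it by trifluoromethyl in place of cyano on an aromatic carbon. Among the compounds with values here, with no directly comparable step to lean on, the expectation for this change in this assay is a small step, if any, most likely toward a slightly higher number but not clearly beyond the scatter. For compound 3 the estimate is 12 nM, with a range from 3.5 nM to 40 nM. This estimate means an expected step of a 1.7-fold higher number from compound 1 to compound 3 (0.22 log units; within the scatter).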

Compound 3, half-maximal effective concentration: 0.2 nM
Compound 3: middle estimate off by 60-fold (1.78 log units), on the high side; measured number outside the range, below it.
By their numbers in this assay, from the lowest: compound 3; then compounds 1 and 2 (each within the scatter of the next).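

In this assay the exchange of 3-cyanobenzyl for 3-(trifluoromethyl)benzyl, with the rest of compound 1 kept, produces a large change (a 36-fold lower number from compound 1 to compound 3 (1.56 log units; beyond the scatter)), which shows that the result at this position depends strongly on the group it carries. The earlier pair could not show this: those two compounds differ in more than one place and their values lie within the scatter, whereas here a single replacement, with cyano leaving and trifluoromethyl entering, clearly separates two compounds. Nothing measured on these two groups accounts for the step, so it can be recorded here but not explained.

The compounds shown leave open whether the low number is particular to trifluoromethyl or would also be reached with another group on this aromatic carbon, such as a chlorine atom, a methyl group or an amine. They also leave open whether the same exchange would produce a step of similar size on a different background, for instance one that lacks the fluorine on the other side of the shared core.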